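The source may hold more compounds than are shown below. What is called first, only, known or untested is meant among the compounds shown, and "the series" means these compounds.

Compounds measured so far in a functional assay on HeLa cells (Homo sapiens) for antiproliferative activity, read by MTT assay, with a stated time of 24 h; a lower number here means a stronger inhibitor, a higher number a weaker inhibitor:

- compound 1 `Cc1ccc(-c2nn(-c3ccccc3)cc2-c2nc3ccccc3n2S(=O)(=O)c2ccc(C)cc2)cc1` gives 480 nM
- compound 2 `Cc1ccc(-c2nn(-c3ccccc3)cc2-c2nc3ccccc3n2S(=O)(=O)c2cc(C)ccc2C)cc1` gives 370 nM
- compound 3 `Cc1ccc(-c2nn(-c3ccccc3)cc2-c2nc3ccccc3n2S(=O)(=O)c2ccc(Cl)cc2)cc1` gives 4060 nM

Compound 3 carries the highest number of the three, and it stands apart from both of the others by more than the scatter. The two methyl-bearing compounds cannot be separated, with a 1.3-fold lower number from compound 1 to compound 2 (0.11 log units; within the scatter).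

The next compound, compound 4 `Cc1ccc(-c2nn(-c3ccccc3)cc2-c2nc3ccccc3n2S(=O)(=O)c2ccc(Br)cc2)cc1`, keeps the shared core and alters one group of compound 3: bromo in place of chloro on an aromatic carbon. This places bromo in place of chloro on an aromatic carbon, turning (4-chlorophenyl)sulfonyl into (4-bromophenyl)sulfonyl.

For the measured compounds named here, no measured step exchanges one halogen for another, so the data give no direct reading of this change. Two steps do arrive at the chloro compound from other groups on the sulfonyl sulfur. One is modest, an 8.5-fold higher number from compound 1 to compound 3 (0.93 log units; beyond the scatter), and the other is large, an 11-fold higher number from compound 2 to compound 3 (1.04 log units; beyond the scatter). Those steps show that the number can move widely with changes in this group, so the expected range is kept broad.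

A swap of one halogen for another is nevertheless expected to stay small. The estimated step is a 1.4-fold lower number from compound 3 to compound 4 (0.13 log units; within the scatter), which would lie within the scatter. For compound 4 the expected value is 3000 nM, with an estimated range from 900 nM to 8000 nM.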

Compound 4, half-maximal inhibitory concentration: 2340 nM
For compound 4 the middle estimate is 1.3-fold (0.11 log units) above the measured one; low and high end bracket the measured number.
By their numbers in this assay, from the lowest: compounds 2 and 1 (each within the scatter of the next); then compounds 4 and 3 (each within the scatter of the next).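

For the compounds shown here, the bromo for chloro exchange gives the first direct reading of one halogen replacing another at this place, para to a large group, and in this assay the two halogen-bearing compounds cannot be separated (a 1.7-fold lower number from compound 3 to compound 4 (0.24 log units; within the scatter)). The bromo group also stands apart from both methyl-bearing sulfonyl groups (a 4.9-fold higher number from compound 1 to compound 4 (0.69 log units; beyond the scatter)) (a 6.3-fold higher number from compound 2 to compound 4 (0.80 log units; beyond the scatter)), so the separation first seen with chloro recurs with a second halogen, and none of the four compounds goes against this split. The data shown offer no measurement that accounts for this split between the halogen-bearing and methyl-bearing compounds. Going by these compounds, whether the split extends to fluoro, or to a group of another kind such as an amine, a methoxy group or a carboxylic acid on the same ring, remains open. On these data alone, it is also open whether the near-equivalence of chloro and bromo would hold with a halogen elsewhere on this ring, or whether it would carry over to an assay other than this assay on these cells.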